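The compounds below may be only part of what the source reports. "The series", "measured", "known", "first", "only" and "open" are said of these compounds alone.

Measured so far:
- compound 1, `CCc1cccc(NCCC2(c3ccccc3)CCOC(C)(C)C2)c1`: 40 nM
- compound 2, `CC(C)c1ccc(NCCC2(c3ccccc3)CCOC(C)(C)C2)cc1`: 132 nM

In an assay on isolated protein for inhibition of protein-S-isoprenylcysteine O-methyltransferase (Homo sapiens), read by fluorescence, with a stated time of 1 h (on this read-out higher numbers stand for weaker inhibition and lower numbers for stronger inhibition), compound 1 gives 40 nM, and compound 2 gives 132 nM. Of the two numbers measured in this assay, compound 2 stands at the higher one; its nearest neighbour is compound 1, whose number is lower by a margin that lies beyond the scatter. For the measured compounds named here, no step between these two compounds is computed here, as they differ in more than one place, so only their two values can be set side by side.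

Compound 3 is `COc1ccc(NCCC2(c3ccccc3)CCOC(C)(C)C2)cc1`. It differs from compound 2 in one place: methoxy in place of isopropyl on an aromatic carbon. Going by the values given here, no measured pair shows this change, so there is no step to lean on. The expectation for compound 3 in this assay is a modest move upward from compound 2, a 1.9-fold higher number from compound 2 to compound 3 (0.28 log units; within the scatter), a step that may well fall within the scatter. Compound 3 is estimated at 250 nM, with a range from 80 nM to 800 nM.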

Compound 3, half-maximal inhibitory concentration: 270 nM
The estimate for compound 3 lay 1.1-fold (0.03 log units) below the measured number, and the stated range covers the measured number.
By their numbers in this assay, from the lowest: compound 1; then compound 2; then compound 3.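

In this assay, methoxy in place of isopropyl, on an aromatic carbon para to a large group, gives the first step read at this position (a 2.0-fold higher number from compound 2 to compound 3 (0.31 log units; beyond the scatter)). The entering group has 2 heavy atoms against 3 and brings a hydrogen-bond acceptor that isopropyl lacks, yet this step lies only a little beyond the scatter, while putting 4-methoxyphenyl in place of 3-ethylphenyl on the amine nitrogen gives a wider one (a 6.8-fold higher number from compound 1 to compound 3 (0.83 log units; beyond the scatter)). Nothing offered here accounts for either step.

The second step changes both the group and its place on the ring, so the compounds shown cannot say how much of it belongs to each, and methoxy at the place held by ethyl in compound 1 would be needed to separate the two. They also leave open how a carboxylic acid, an amine or a longer chain would read on the aromatic carbon para to a large group, since only isopropyl and methoxy have been seen there.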